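A Longer Chain Ending in Selenium on the Shared Core

This account rests on a few compounds, and the source may have more. Where it says the series, first, only, none or still open, it means among the compounds named here.

In a functional assay on HepG2 cells (Homo sapiens) for antiproliferative activity, read by MTT assay, with a stated time of 48 h (a higher number here means a weaker inhibitor, a lower number a stronger inhibitor), compound 1 `COc1ccc(N(C)c2ccnc(Cl)n2)cc1[N+](=O)[O-]` gives 6120 nM, and compound 2 `COc1ccc(N(C)c2ccnc(Cl)n2)cc1OCCCBr` gives 1240 nM. Among the measured compounds shown here, compound 2 stands lowest of the two numbers measured so far, its nearest neighbour being compound 1, because the single measured step, a 4.9-fold lower number from compound 1 to compound 2 (0.69 log units; beyond the scatter), is a modest one in the downward direction.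

Compound 3 `COc1ccc(N(C)c2ccnc(Cl)n2)cc1OCCCCC[Se]C#N` differs from compound 2 as follows: a group of 5 heavy atoms (3 carbon, 1 nitrogen, 1 selenium; no ring) in place of one bromine atom, on a saturated chain carbon, three bonds along the chain from an oxygen on an aromatic ring. For the measured compounds named here, no measured step concerns this kind of replacement; the only step in hand, a 4.9-fold lower number from compound 1 to compound 2 (0.69 log units; beyond the scatter), tells that an exchange on the aromatic ring at this part of the core moved the number by a modest amount, and it offers no direct guide to an exchange at the end of the saturated chain. With the entering group replacing a single bromine atom on a chain that is otherwise retained, he therefore expects a step of modest size, if any, more likely downward than upward, and gives a 1.6-fold lower number from compound 2 to compound 3 (0.19 log units; within the scatter) as his estimate. For compound 3, he expects 800 nM in this assay, within a range from 250 nM to 2500 nM.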

Compound 3, half-maximal inhibitory concentration: > 10000 nM
Compound 3 was reported as a limit; the forecaster's own chance of this, stated with the estimate: 5%; middle value at least 12-fold (1.09 log units) away from the limit.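

Compound 3 is reported in this assay as a limit, not as a number: the limit of > 10000 nM in this assay, at which 1 of the 3 values shown sits. Among the compounds shown here, the result gives an at least 8.0-fold higher number from compound 2 to compound 3 (0.90 log units; beyond the scatter), the first measured change at the end of the saturated chain, and it shows that this end is not indifferent to what it carries, with a step that runs upward where the only earlier step, a 4.9-fold lower number from compound 1 to compound 2 (0.69 log units; beyond the scatter), on an aromatic carbon, ran downward. The entering group lengthens the chain as well as replacing the bromine with a selenium and nitrile end, so this single step joins two changes and does not divide them.

The compounds shown leave open whether the rise follows the longer chain or the selenium end; a longer chain ending in bromine, or the 3-bromopropoxy chain with its bromine exchanged for the selenium and nitrile end, would separate the two. Also open, from the compounds shown here alone, is whether an amine or a carboxylic acid at the end of the chain would keep the number close to that of compound 2.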